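Chloro to fluoro: the next step in the series

The source may report more compounds than this note shows. Statements on the series, on what has been measured and on what is new or still open speak of the compounds shown alone.

Two compounds of the series have numbers in an assay on liver for inhibition of sterol O-acyltransferase 1 (Rattus norvegicus), using microsomes; on this read-out lower numbers stand for stronger inhibition and higher numbers for weaker inhibition. Compound 1 `CC(C)c1cc(C(C)(C)C)cc(C(C)C)c1OC(=O)NS(=O)(=O)Oc1c(C(C)C)cccc1C(C)C` gives 8800 nM in this assay, while compound 2 `CC(C)c1cc(Cl)cc(C(C)C)c1OC(=O)NS(=O)(=O)Oc1c(C(C)C)cccc1C(C)C` gives 42000 nM. Between them lies one change, chloro in place of tert-butyl on an aromatic carbon, and it moves the number by a 4.8-fold higher number from compound 1 to compound 2 (0.68 log units; beyond the scatter). Among the compounds with values here, compound 2 thus stands at the higher of the two numbers, with compound 1 as its only neighbour.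

Compound 3 `CC(C)c1cc(F)cc(C(C)C)c1OC(=O)NS(=O)(=O)Oc1c(C(C)C)cccc1C(C)C` is not yet measured. It differs from compound 2 by fluoro in place of chloro on an aromatic carbon, a fluoro in place of chloro on an aromatic carbon, meta to two isopropyl groups and para to a large group. Within the data shown here, no measured step involves a fluoro at this place; the only step that bears on it is the one from tert-butyl to chloro, of a 4.8-fold higher number from compound 1 to compound 2 (0.68 log units; beyond the scatter), which is the only guide to how this position tolerates a change. For compound 3 a step of a 1.4-fold higher number from compound 2 to compound 3 (0.15 log units; within the scatter) is expected, a modest move toward a higher number that may not exceed the scatter. The estimate for compound 3 in this assay is 60000 nM, within a range from 20000 nM to 180000 nM.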

Compound 3, half-maximal inhibitory concentration: > 50000 nM
Compound 3 was reported as a limit; the forecaster's own chance of this, stated with the estimate: 20%; the middle value is on the limit's open side.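

Compound 3 is reported in this assay only as a limit: the limit of > 50000 nM in this assay, at which 1 of the 3 values shown sits. Against compound 2 this gives an at least 1.1-fold higher number from compound 2 to compound 3 (0.07 log units; that floor lies within the scatter), so the change from chloro to fluoro has no readable size; the floor of this step lies within the scatter, and the true step may or may not exceed it. Against the tert-butyl compound the reading is firmer, with an at least 5.6-fold higher number from compound 1 to compound 3 (0.75 log units; beyond the scatter), so a second group at this place, fluoro as well as chloro, leaves the number beyond the scatter on the higher side of compound 1, and neither of the two compounds goes against that.

The compounds shown contain only tert-butyl, chloro and fluoro at this place, so they cannot tell whether the read-out follows a trend across these groups or whether tert-butyl is itself a favourable choice. As far as these compounds go, how a methyl group, a longer alkyl chain, a methoxy group, an amine or a carboxylic acid would fare at the same carbon remains open, as does whether any of them would give a number lower than that of compound 1.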